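A few compounds are considered here, and "the series" means these few. Any claim that something is new, unique, unknown or untested is made for them only; others in the source may bear on it.

Working notes on a small series sharing one core. In a functional assay on KB 3-1 cells (Homo sapiens) for cytotoxicity, read by MTT assay, with a stated time of 72 h (a lower number here means a stronger inhibitor, a higher number a weaker inhibitor), compound 3 (`O=C1Nc2ccccc2/C1=N/NC(=S)Nc1ccccc1`) gives 3530 nM and compound 1 (`O=C1Nc2ccccc2/C1=N/NC(=S)Nc1cccc2ccccc12`) gives 5120 nM while compound 2 (`O=C1Nc2ccccc2/C1=N/NC(=S)Nc1ccc2c(c1)CCC2`) gives 5800 nM on the same read-out. These three values lie within the scatter of one another, so compound 3 stands level with compound 1 and compound 2. Among the measured compounds shown here, no pair of measured compounds differs in one place, so no measured step is available as a guide.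

Compound 4 (`O=C1Nc2ccccc2/C1=N/NC(=S)Nc1cccnc1`) departs from compound 3 in one place (pyridin-3-yl in place of phenyl on an amide-type nitrogen), with pyridin-3-yl in place of phenyl on an amide-type nitrogen.

The expected step of a 1.4-fold higher number from compound 3 to compound 4 (0.15 log units; within the scatter) is small, leaning toward a higher number but not expected to go beyond the scatter. That direction is held loosely, and the wide range reflects the lack of a measured step. The estimated value for compound 4 is 5000 nM with an expected range from 2000 nM to 14000 nM on this read-out.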

Compound 4, half-maximal inhibitory concentration: > 50000 nM
Compound 4: a limit, no number; the forecaster's own chance of this, stated with the estimate: 3%; at least 10-fold (1.00 log units) between middle value and limit.
By their numbers in this assay, from the lowest: compounds 3, 1 and 2 (each within the scatter of the next). At a limit, above all of these: compound 4.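

The ring on the amide-type nitrogen, whose other neighbour is the thiocarbonyl carbon, proves sensitive to a single change in this assay: pyridin-3-yl in place of phenyl gives an at least 14-fold higher number from compound 3 to compound 4 (1.15 log units; beyond the scatter), something compounds 1, 2 and 3, with values within the scatter of one another, did not reveal. Compound 4 reads > 50000 nM, which is a limit of the assay and not a number. The step therefore gives only a minimum size, and it rests on that limit: the limit of > 50000 nM in this assay, at which 1 of the 4 values shown sits.

Still open, going by these compounds, is whether this holds for other ring nitrogen placements, as in pyridin-2-yl or pyridin-4-yl, or for a phenyl ring carrying an amine or a carboxylic acid. The compounds shown also leave the actual value of compound 4 unresolved.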